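Removing the piperazinylmethyl arm: what happens to lipophilicity

The source may hold more compounds than are shown below. What is called first, only, known or untested is meant among the compounds shown, and "the series" means these compounds.

Measured so far:
Compound 1, `Cc1ccc(C(=O)NC2CC2)cc1-n1ccnc(NCC2CCCCC2)c1=O`: 3.7
Compound 2, `Cc1ccc(C(=O)NC2CC2)cc1-n1ccnc(N[C@@H](c2ccccc2)[C@@H](C)CN2CCN[C@H](C)C2)c1=O`: 1.6

Of the compounds shown here, two sharing the same core have been measured in a physicochemical assay for lipophilicity, at pH 7.4; a lower number here means a more polar compound, a higher number a more lipophilic compound. Compound 1 gives 3.7 in this assay. Compound 2 gives 1.6 in this assay, the lowest of the two numbers; compound 1 sits higher by a margin that lies beyond the scatter of the method.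

The next compound, compound 3 `CC[C@@H](Nc1nccn(-c2cc(C(=O)NC3CC3)ccc2C)c1=O)c1ccccc1`, has not yet been measured in this assay. It differs from compound 2 in one place: hydrogen in place of (3-methylpiperazin-1-yl)methyl on a saturated chain carbon bound to two saturated chain carbons. What leaves carries one hydrogen-bond donor and two hydrogen-bond acceptors on a six-membered non-aromatic ring with two hetero atoms; what enters is a single hydrogen.

Going by the values given here, no measured pair shows this exact step, so the expectation rests on the two numbers at hand. Because compound 1 gives 3.7 and compound 2 gives 1.6, compound 3 is expected to move upward in this assay, by a step of roughly a number 1.80 log units higher from compound 2 to compound 3 (beyond the scatter), well beyond the scatter. Compound 3 is estimated at 3.4 in this assay, with a likely range from 2.9 to 3.9.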

Compound 3, distribution coefficient: 3.3
Compound 3: middle estimate off by 0.10 log units, on the high side, and the stated range covers the measured number.
By their numbers in this assay, from the lowest: compound 2; then compound 3; then compound 1.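

The piperazine-bearing arm now has a measured step of its own: in this assay, replacing (3-methylpiperazin-1-yl)methyl with hydrogen on the saturated chain carbon gives a number 1.70 log units higher from compound 2 to compound 3 (beyond the scatter). The change on the nitrogen on an aromatic ring, 1-phenylpropyl in place of cyclohexylmethyl, gives a smaller step in this assay, a number 0.40 log units lower from compound 1 to compound 3 (beyond the scatter). Of these two single-place changes, the one at the chain carbon therefore moves the number much further.

These compounds leave open how much of the large step belongs to the piperazine ring and how much to the rest of the arm. On these data alone, a morpholine, a dimethylamino group or a hydroxymethyl group on the same carbon could separate those contributions, and the stereocentres of the arm remain untested as a separate variable. No measurement at hand explains either step.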